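This account rests on a few compounds, and the source may have more. Where it says the series, first, only, none or still open, it means among the compounds named here.

Compound 3 `Cc1ccc2c(Cc3nn4c(CO)c(-c5ccc(Cl)cc5)nc4s3)coc2c1` stands highest of the three compounds measured in a functional assay on the whole organism (strain Wistar albino) for inhibition, with Rattus norvegicus as the target, read by paw edema, with a stated time of 3 h, at a dose of 100 mg/kg by the oral route; on this read-out lower numbers stand for less inhibition and higher numbers for more inhibition at the one dose given (going by the name of the read-out): compound 3 gives 45.9%. Compound 1 `Cc1ccc2c(Cc3nn4cc(-c5ccc(Br)cc5)nc4s3)coc2c1` gives 10.9%, and compound 2 `Cc1ccc2c(Cc3nn4c(C=O)c(-c5ccc(Br)cc5)nc4s3)coc2c1` gives 10.9%, both well below compound 3 and beyond the scatter. Among the compounds with values here, the single step recorded between compounds that differ in one place is no change at the digits printed from compound 1 to compound 2 (within the scatter), a change from hydrogen to formyl that says nothing about a halogen.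

Compound 4 `Cc1ccc2c(Cc3nn4c(CO)c(-c5ccc(Br)cc5)nc4s3)coc2c1` has not been measured. It differs from compound 3 by bromo in place of chloro on an aromatic carbon. Within the data shown here, no measured pair differs only in this way: compound 1 and compound 2 carry bromo, but each also differs from compound 3 in the group on the other aromatic carbon, so their lower numbers cannot be laid on the halogen alone. The exchange of one halogen for another of the same count of heavy atoms, with no change in donors, acceptors or charge, gives no measured reason to expect a large move in this assay. Compound 4 is therefore expected to sit close to compound 3, with a step of a number 3.9 percentage points lower from compound 3 to compound 4 (within the scatter) within the scatter. The estimate for compound 4 is 42%, ranging from 25% to 58%.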

Compound 4, a percentage reported as inhibition, in the whole organism at one dose (the size of the read-out at that dose, not a potency): 36.7%
The estimate for compound 4 lay 5.3 percentage points above the measured number; the measured number falls inside the stated range.
By their numbers in this assay, from the lowest: compounds 1 and 2 (each within the scatter of the next); then compounds 4 and 3 (each within the scatter of the next).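

In this assay, within the data shown here, the change from 4-chlorophenyl to 4-bromophenyl gives a number 9.2 percentage points lower from compound 3 to compound 4 (within the scatter), the first reading of this exchange alone, on an aromatic carbon para to a large group, with hydroxymethyl held in place on the other aromatic carbon. With bromo held constant, the group on that other carbon does separate the compounds: hydroxymethyl in place of formyl gives a number 25.8 percentage points higher from compound 2 to compound 4 (beyond the scatter), and hydroxymethyl in place of hydrogen gives a number 25.8 percentage points higher from compound 1 to compound 4 (beyond the scatter), so the low numbers of the two earlier bromo compounds cannot be laid on the bromo group. Nothing measured here explains why the hydroxymethyl compounds give the higher numbers.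

The compounds shown leave open whether an aminomethyl group, a carboxylic acid or a longer chain such as hydroxyethyl on that carbon would give a number like that of hydroxymethyl or like that of formyl. They also leave open how fluoro or methoxy would read in place of the halogen, and, with a single oral dose and a single time, how these steps would appear at other doses or times.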